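Compound 1 to compound 3: halogen swap on a non-toxic frame

A few compounds are considered here, and "the series" means these few. Any claim that something is new, unique, unknown or untested is made for them only; others in the source may bear on it.

Compound 1 `CCOC(=O)/C(=C/c1ccccc1)CN1C(=O)[C@@H](OC)[C@H]1c1ccc(F)cc1` has no single number in an ADME assay on cells (Epithelial cell, Homo sapiens) for antiproliferative activity, read by MTT assay, with a stated time of 48 h; on this read-out higher numbers stand for weaker inhibition and lower numbers for stronger inhibition; there compound 1 is recorded as "not toxic" (no number reported). Compound 2 `CO[C@@H]1C(=O)N(C/C(C#N)=C/c2ccccc2)[C@@H]1c1ccc(Cl)cc1Cl` reaches only a limit of this assay, > 100000 nM. The one limit shown, (the limit of > 100000 nM in this assay, at which 1 of the 2 values shown sits), is where one of the two values rests. Compound 3 `CCOC(=O)/C(=C/c1ccccc1)CN1C(=O)[C@@H](OC)[C@H]1c1ccccc1Br` differs from compound 1 by 2-bromophenyl in place of 4-fluorophenyl on a saturated ring carbon. For the measured compounds named here, no measured step between compounds exists, so no step size can be read from the data; the change is expected to leave the read-out near the top of the range, with no shift beyond the scatter anticipated. Compound 3 is therefore estimated at 100000 nM, within 30000 nM to 300000 nM.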

Compound 3, half-maximal inhibitory concentration: 66600 nM
Compound 3: the middle estimate sits 1.5-fold (0.18 log units) above what was measured, within the range that was stated.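

For the compounds shown here, compound 1 carries no number in this assay, so no step to compound 3 can be read. Whether 2-bromophenyl in place of 4-fluorophenyl shifts the read-out stays open, and one value shown remains only a limit: the limit of > 100000 nM in this assay, at which 1 of the 3 values shown sits.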